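Adding a carbamoyl amino link to a fluorophenyl urea

A few compounds are considered here, and "the series" means these few. Any claim that something is new, unique, unknown or untested is made for them only; others in the source may bear on it.

Values measured in a functional assay on HeLa cells (Homo sapiens) for inhibition, read by MTT assay, with a stated time of 72 h; a higher number here means a weaker inhibitor, a lower number a stronger inhibitor:
- compound 1 `COc1cc(NC(C)CCCNC(=O)NNC(=O)Nc2ccc(F)cc2)c2ncccc2c1`: >= 250000 nM (a limit)
- compound 2 `COc1cc(NC(C)CCCNC(=O)NNC(=O)Nc2ccc(C(F)(F)F)cc2)c2ncccc2c1`: 15000 nM
- compound 3 `COc1cc(NC(C)CCCNC(=O)Nc2ccc(F)cc2)c2ncccc2c1`: 20000 nM

Compound 1 gives >= 250000 nM, which is a limit of the assay and not a number. Compound 3, at 20000 nM, lies within the scatter of compound 2, at 15000 nM. Both stand well clear of that limit on the side of stronger inhibition.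

The next candidate is compound 4 `COc1cc(NC(C)CCCNC(=O)NNC(=O)Nc2cccc(F)c2)c2ncccc2c1`. Its change is ((3-fluorophenyl)carbamoyl)amino in place of 4-fluorophenyl on an amide-type nitrogen. The closest guide is an at least 12-fold lower number from compound 1 to compound 3 (1.09 log units; beyond the scatter), which exchanges the same kind of group in the opposite direction, so a large move back toward weaker inhibition is expected in this assay. The step of an at least 16-fold lower number from compound 1 to compound 2 (1.22 log units; beyond the scatter) shows that a change on the aromatic ring alone can also shift the value strongly, so the expectation stays broad.

The estimated change is a 5.0-fold higher number from compound 3 to compound 4 (0.70 log units; beyond the scatter). The estimate for compound 4 is 100000 nM, with an expected range of 25000 nM to 250000 nM.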

Compound 4, half-maximal inhibitory concentration: > 250000 nM
Compound 4 gave a limit, no number; the forecaster's own chance of this, stated with the estimate: 40%; middle value at least 2.5-fold (0.39 log units) from the limit.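

In this assay, compound 4 gives > 250000 nM, which is a limit of the assay and not a number. The result extends the earlier picture to a second ring pattern: with ((3-fluorophenyl)carbamoyl)amino on the amide-type nitrogen, the data show an at least 12-fold higher number from compound 3 to compound 4 (1.09 log units; beyond the scatter), and also an at least 16-fold higher number from compound 2 to compound 4 (1.22 log units; beyond the scatter), so 4-(trifluoromethyl)phenyl remains the only ring group shown that keeps a measurable value with this longer link. Compound 1 and compound 4 both end at limits, and the step between them cannot be read, so moving the fluorine on the ring shows no readable effect here.

From the compounds shown here alone, how much the ring position matters therefore stays open, as no value is available for either fluorine compound with this link. Also open, going by these compounds, is whether a chloro group, a methoxy group or an amine on the ring would give a measurable value with this link.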